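A Chloroaryl Chalcone Follows a Trimethoxy Analogue

The compounds below may be only part of what the source reports. "The series", "measured", "known", "first", "only" and "open" are said of these compounds alone.

Two measured compounds frame this account. Compound 1 `COc1cc(/C=C/C(=O)c2ccc(OCC(O)CNCCNc3ccnc4cc(Cl)ccc34)cc2)cc(OC)c1OC` and compound 2 `COc1cc(/C=C/C(=O)c2ccccc2OCC(=O)NCCNc2ccnc3cc(Cl)ccc23)cc(OC)c1OC` were both examined in an ADME assay on Vero cells (Chlorocebus sabaeus) for cytotoxicity, read by MTT assay, with a stated time of 72 h; a lower number here means that less compound is tolerated, a higher number that more compound is tolerated. In this assay compound 1 gives 1910 nM, and compound 2 gives 3920 nM. Compound 2 thus holds the highest of the two numbers, with compound 1 as its nearest neighbour at a gap beyond the scatter.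

Compound 3 `O=C(COc1ccccc1C(=O)/C=C/c1ccc(Cl)cc1)NCCNc1ccnc2cc(Cl)ccc12` has not yet been measured. It differs from compound 2 in a single place: 4-chlorophenyl in place of 3,4,5-trimethoxyphenyl on a double-bonded chain carbon bound to a double-bonded chain carbon. The 4-chlorophenyl takes the spot of the 3,4,5-trimethoxyphenyl on a double-bonded chain carbon bound to a double-bonded chain carbon, and the rest of the shared core is unchanged.

Within the data shown here, no measured pair shows this change, so the expectation rests on compound 2 alone. In this assay the expected step is a 1.4-fold lower number from compound 2 to compound 3 (0.15 log units; within the scatter), a modest move toward a lower number that need not exceed the scatter. Compound 3 is accordingly estimated at 2800 nM in this assay, within a range from 1000 nM to 8000 nM.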

Compound 3, half-maximal cytotoxic concentration: 4980 nM
For compound 3 the middle estimate is 1.8-fold (0.25 log units) below the measured one; the range from low to high includes it.
By their numbers in this assay, from the lowest: compound 1; then compounds 2 and 3 (each within the scatter of the next).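

In this assay the 4-chlorophenyl in place of 3,4,5-trimethoxyphenyl gives a 1.3-fold higher number from compound 2 to compound 3 (0.10 log units; within the scatter) and so shows that, on a double-bonded chain carbon bound to a double-bonded chain carbon, this exchange leaves the number within the scatter. The entering group has 7 heavy atoms and 0 hydrogen-bond acceptors against 12 heavy atoms and 3 hydrogen-bond acceptors in the group that leaves, and this difference in counts comes with no step beyond the scatter. Nothing at hand offers an explanation for this result.

On these data alone, whether a phenyl carrying an amine or a carboxylic acid would also stay within the scatter at this place remains open. Also open, as far as these compounds go, is whether 4-chlorophenyl would give a similar step on the core of compound 1.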